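Swapping the benzyl chlorines: compound 4 against compound 3

The source may hold more compounds than are shown below. What is called first, only, known or untested is meant among the compounds shown, and "the series" means these compounds.

Of the compounds shown here, three sharing one core have been measured in a functional assay on LNCaP cells (Homo sapiens) for cytotoxicity, read by MTT assay; a higher number here means a weaker inhibitor, a lower number a stronger inhibitor. Compound 1 `COc1ccc2cc([C@H](C)c3nnc(SCc4ccc(C)cc4)n3-c3ccc(Cl)cc3)ccc2c1` gives 52200 nM, compound 2 `COc1ccc2cc([C@H](C)c3nnc(SCc4c(Cl)cccc4Cl)n3-c3ccc(F)cc3)ccc2c1` gives 12300 nM, and compound 3 `COc1ccc2cc([C@H](C)c3nnc(SCc4ccc(Cl)cc4)n3-c3ccc(Cl)cc3)ccc2c1` gives 110000 nM. Compound 3 therefore holds the highest number of the three; its nearest neighbour is compound 1 and its furthest is compound 2. Going by the values given here, the one step measured in a single place, a 2.1-fold higher number from compound 1 to compound 3 (0.32 log units; beyond the scatter), concerns the substituent on the benzyl group and is modest.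

Compound 4 `COc1ccc2cc([C@H](C)c3nnc(SCc4c(Cl)cccc4Cl)n3-c3ccc(Cl)cc3)ccc2c1` is obtained from compound 3 by a different change: 2,6-dichlorophenyl in place of 4-chlorophenyl on a saturated chain carbon bound to a sulfur. Among the compounds with values here, no measured step covers exactly this change. What bears on it is compound 2, which carries the same 2,6-dichlorobenzyl group but a 4-fluorophenyl instead of the 4-chlorophenyl on the core, and which shows by far the lowest number of the three. Since compound 2 and compound 3 differ in two places, only their values can be compared, not a single step.

On that basis compound 4 is expected to move downward from compound 3 by roughly a 5.5-fold lower number from compound 3 to compound 4 (0.74 log units; beyond the scatter) in this assay, landing near compound 2. The estimate for compound 4 is 20000 nM, with a range from 7000 nM to 60000 nM.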

Compound 4, half-maximal inhibitory concentration: > 400000 nM
Compound 4: no number, only a limit; the forecaster's own chance of this, stated with the estimate: 5%; middle value at least 20-fold (1.30 log units) from the limit.
By their numbers in this assay, from the lowest: compound 2; then compound 1; then compound 3. At a limit, above all of these: compound 4.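

In this assay compound 4 gives > 400000 nM, which is a limit of the assay and not a number: the limit of > 400000 nM in this assay, at which 1 of the 4 values shown sits.

With the 2,6-dichlorobenzyl group held constant, the change of a single halogen on an aromatic carbon gives an at least 32-fold higher number from compound 2 to compound 4 (1.51 log units; beyond the scatter), the largest step in this series, so the low number of compound 2 does not come from the 2,6-dichlorobenzyl group alone. On a saturated chain carbon bound to a sulfur, with the 4-chlorophenyl on the core kept, 2,6-dichlorophenyl gives an at least 3.6-fold higher number from compound 3 to compound 4 (0.56 log units; beyond the scatter) when it replaces 4-chlorophenyl and an at least 7.6-fold higher number from compound 1 to compound 4 (0.88 log units; beyond the scatter) when it replaces 4-methylphenyl, so both of these changes go upward.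

As far as these compounds go, the limit leaves the full size of all three steps open, and it remains open whether fluoro in place of chloro would lower the number to a similar extent with a 4-chlorobenzyl or 4-methylbenzyl group. The compounds shown also do not tell how an amine or a carboxylic acid on the benzyl ring would read in this assay.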